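Dropping a Methyl: Expected Effect on Growth Inhibition

This account rests on a few compounds, and the source may have more. Where it says the series, first, only, none or still open, it means among the compounds named here.

Measured so far:
- compound 1, `N/C(=N\NC(=S)N1CCOCC1)c1ccccn1`: 82.8% in a functional assay on HeLa cells (Homo sapiens) for cytotoxicity, read by MTT assay, with a stated time of 72 h, tested at 30 uM; a higher number here means more inhibition of growth at the concentration tested, a lower number less inhibition of growth
- compound 2, `Cc1cccc(/C(N)=N/NC(=S)N2CCOCC2)n1`: 86.9% in this assay
- compound 3, `Cc1cccc(/C(N)=N/NC(=S)N2CCCC2)n1`: 74.5% in this assay

Compound 4, `N/C(=N\NC(=S)N1CCCC1)c1ccccn1`, has not been measured. It differs from compound 3 in one place: hydrogen in place of methyl on an aromatic carbon. The same change has already been seen once, between compound 2 and compound 1: hydrogen in place of methyl on an aromatic carbon, and there it gave a number 4.1 percentage points lower from compound 2 to compound 1 (within the scatter). The two cores on which the change is made differ from each other: pyrrolidin-1-yl in place of morpholin-4-yl on a thiocarbonyl carbon, a change that gave a number 12.4 percentage points lower from compound 2 to compound 3 (beyond the scatter). Compound 3 carries the lowest number of the three, though its gap to compound 1 is within the scatter. Both occurrences of the methyl-to-hydrogen change sit at the same kind of place on the same kind of ring, so the step from compound 3 to compound 4 is expected to be small, a number 3.5 percentage points lower from compound 3 to compound 4 (within the scatter), because a number 4.1 percentage points lower from compound 2 to compound 1 (within the scatter) stayed within the scatter. Compound 4 is therefore estimated to give 71%, within a range from 58% to 82%.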

Compound 4, percent growth inhibition at one concentration: 84.5%
Beside the measured number, compound 4's estimate is 13.5 percentage points below it, outside the stated range (above it).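

In this assay, putting hydrogen in place of methyl gives a number 10 percentage points higher from compound 3 to compound 4 (within the scatter), and putting pyrrolidin-1-yl in place of morpholin-4-yl on the core without the methyl gives a number 1.7 percentage points higher from compound 1 to compound 4 (within the scatter). Set beside the earlier step, the methyl-to-hydrogen change does not carry over as a fixed amount from one core to the other: the same change on two cores in this assay, a number 4.1 percentage points lower (within the scatter) from compound 2 to compound 1 and a number 10 percentage points higher (within the scatter) from compound 3 to compound 4, 14.1 percentage points apart, beyond the scatter of two such steps. The swap on the thiocarbonyl carbon likewise depends on whether the methyl is present, which shows that the two changes do not simply add up in these four compounds, but it does not show why they fail to add up or whether the same holds beyond them: the same change on two cores in this assay, a number 12.4 percentage points lower (beyond the scatter) from compound 2 to compound 3 and a number 1.7 percentage points higher (within the scatter) from compound 1 to compound 4, 14.1 percentage points apart, beyond the scatter of two such steps.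

The compounds shown leave open how the methyl-to-hydrogen change behaves with other groups on the thiocarbonyl carbon, such as a dimethylamino group or a longer chain. They also leave open what an ethyl group or a chlorine atom would do in place of the methyl on the aromatic carbon.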